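The source may hold more compounds than are shown below. What is called first, only, known or untested is meant among the compounds shown, and "the series" means these compounds.

Of the compounds shown here, two have been measured in a physicochemical assay for solubility, read by spectrophotometry, measured as kinetic solubility, at pH 8, tested at 500 uM; a lower number here means a less soluble compound, a higher number a more soluble compound. Compound 1 `Cn1ccc2ccc(-c3cc(Nc4ccccc4S(=O)(=O)N4CCOCC4)cc4nccnc34)cc21` gives 5 ug/mL in this assay, while compound 2 `Cn1cc(CNC(=O)c2ccncc2Nc2cc(-c3ccc4ccn(C)c4c3)c3nccnc3c2)cn1` gives 127 ug/mL, the higher of the two numbers by a margin beyond the scatter. Compound 3 `CC(=O)N1CC(NC(=O)c2ccncc2Nc2cc(-c3ccc4ccn(C)c4c3)c3nccnc3c2)C1` has not yet been measured. It differs from compound 2 in one place: 1-acetylazetidin-3-yl in place of (1-methyl-1H-pyrazol-4-yl)methyl on an amide-type nitrogen. For the measured compounds named here, no measured pair shows this difference, so the size of the step is uncertain. The step from compound 2 to compound 3 is expected to be small, a 1.2-fold higher number from compound 2 to compound 3 (0.07 log units; within the scatter), within the scatter. Compound 3 is therefore estimated at 150 ug/mL, with a range from 60 ug/mL to 250 ug/mL.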

Compound 3, solubility: 244 ug/mL
Beside the measured number, compound 3's estimate is 1.6-fold (0.21 log units) below it; the range from low to high includes it.
By their numbers in this assay, from the lowest: compound 1; then compounds 2 and 3 (each within the scatter of the next).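

In this assay, the amide-type nitrogen now has its first one-place comparison: 1-acetylazetidin-3-yl in place of (1-methyl-1H-pyrazol-4-yl)methyl gives a 1.9-fold higher number from compound 2 to compound 3 (0.28 log units; within the scatter). In this one pair, a four-membered non-aromatic ring thus stands in for a five-membered aromatic ring without a difference that can be told from the scatter. No measurement offers an explanation for this result. The compounds shown leave open how an amine, such as a piperidine, or a carboxylic acid would read on this nitrogen. On these data alone, whether the acetyl group itself matters on the azetidine also remains open.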